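The source may hold more compounds than are shown below. What is called first, only, known or untested is meant among the compounds shown, and "the series" means these compounds.

Compound 3 `O=C(/C=C/c1ccccc1)c1ccc(N2CCN(S(=O)(=O)c3ccc(Cl)cc3)CC2)cc1` stands highest of the three compounds measured in a functional assay on the whole organism (strain Kunming) for inhibition, with Mus musculus as the target, with a stated time of 1 h, at a dose of 40 mg/kg by the oral route (a lower number here means less inhibition, a higher number more inhibition at the dose given (going by the name of the read-out)), at 46.8%. In this assay compound 2 `O=C(/C=C/c1ccccc1)c1ccc(N2CCN(c3cccc(Cl)c3Cl)CC2)cc1` gives 30.7%, and compound 1 `Cc1ccc(N2CCN(c3ccc(C(=O)/C=C/c4ccccc4)cc3)CC2)c(C)c1` gives 15%. The measured steps are a number 31.8 percentage points higher from compound 1 to compound 3 (beyond the scatter), a number 16.1 percentage points higher from compound 2 to compound 3 (beyond the scatter) and a number 15.7 percentage points higher from compound 1 to compound 2 (beyond the scatter); each exchanges the whole group on the amine nitrogen in the ring, and none of them removes a single chloro. Compound 4 `O=C(/C=C/c1ccccc1)c1ccc(N2CCN(S(=O)(=O)c3ccccc3)CC2)cc1` differs from compound 3 by hydrogen in place of chloro on an aromatic carbon. Among the compounds with values here, no measured step bears directly on this change; the sulfonyl that carried the large gain from compound 1 is kept, so only a modest downward step, possibly within the scatter, is expected, a number 8.8 percentage points lower from compound 3 to compound 4 (within the scatter). Compound 4 is estimated at 38%, in the range 22% to 54%.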

Compound 4, a percentage reported as inhibition, in the whole organism at one dose (the size of the read-out at that dose, not a potency): 30%
The estimate for compound 4 lay 8 percentage points above the measured number, and the stated range covers the measured number.
By their numbers in this assay, from the lowest: compound 1; then compounds 4 and 2 (each within the scatter of the next); then compound 3.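

In this assay hydrogen in place of chloro para to a large group gives a number 16.8 percentage points lower from compound 3 to compound 4 (beyond the scatter) and so the chloro accounts for part of the lead of compound 3. Without that chloro, phenylsulfonyl still gives a number 15 percentage points higher from compound 1 to compound 4 (beyond the scatter) in place of 2,4-dimethylphenyl, but a number 0.7 percentage points lower from compound 2 to compound 4 (within the scatter) in place of 2,3-dichlorophenyl, so the sulfonyl alone does not carry the gain over compound 2. Nothing available explains the size of the chloro step.

Open, as far as these compounds go, is whether fluoro, bromo or methoxy in the same place keeps the number of compound 3 or drops to that of compound 4.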